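The source may report more compounds than this note shows. Statements on the series, on what has been measured and on what is new or still open speak of the compounds shown alone.

Measured compounds:
compound 1, `C#CCn1cc(C(=O)NC(CC(=O)Nc2ccccc2)c2ccccc2)c(=O)c2cc(F)c(Cl)nc21`, 6600 nM
compound 2, `C#CCn1cc(C(=O)NC(CC(=O)NC2CCCC2)c2ccccc2)c(=O)c2cc(F)c(Cl)nc21`, 7300 nM
compound 3, `C#CCn1cc(C(=O)NC(CC(=O)Nc2ccccc2)c2ccccc2)c(=O)c2ccc(Cl)nc21`, 7700 nM

The three compounds share a core and were tested in a functional assay on K562 cells (Homo sapiens) for cytotoxicity, read by MTT assay, with a stated time of 72 h; a lower number here means a stronger inhibitor, a higher number a weaker inhibitor. Compound 3 has the highest of the three numbers shown, although its gaps to compound 2 and to compound 1 both fall within the scatter, so the three cannot be ranked against one another. Going from compound 1 to compound 3 gave a 1.2-fold higher number from compound 1 to compound 3 (0.07 log units; within the scatter), and going from compound 1 to compound 2 gave a 1.1-fold higher number from compound 1 to compound 2 (0.04 log units; within the scatter).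

Compound 4, `C#CCn1cc(C(=O)NC(CC(=O)NC2CCCC2)c2ccccc2)c(=O)c2ccc(Cl)nc21`, is not yet measured. It differs from compound 3 in one place: cyclopentyl in place of phenyl on an amide-type nitrogen. The same change, made on compound 1 to give compound 2, produced only a 1.1-fold higher number from compound 1 to compound 2 (0.04 log units; within the scatter), a shift within the scatter. On that single precedent no step beyond the scatter is expected for compound 4 in this assay, and the expected step is a 1.1-fold higher number from compound 3 to compound 4 (0.04 log units; within the scatter). Compound 4 is therefore estimated at 8500 nM, with a range from 4000 nM to 18000 nM.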

Compound 4, half-maximal inhibitory concentration: 6800 nM
Compound 4: the middle estimate sits 1.3-fold (0.10 log units) above what was measured; the range from low to high includes it.
By their numbers in this assay, from the lowest: compounds 1, 4, 2 and 3 (each within the scatter of the next).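

In this assay cyclopentyl in place of phenyl on the amide-type nitrogen, now read on the core without fluoro, gives a 1.1-fold lower number from compound 3 to compound 4 (0.05 log units; within the scatter) and stays within the scatter on both cores: the same change on two cores in this assay, a 1.1-fold higher number (0.04 log units; within the scatter) from compound 1 to compound 2 and a 1.1-fold lower number (0.05 log units; within the scatter) from compound 3 to compound 4, 1.3-fold (0.10 log units) apart, within the scatter of two such steps. Hydrogen in place of fluoro on the aromatic carbon, now read with cyclopentyl as well as with phenyl on that nitrogen, gives a 1.1-fold lower number from compound 2 to compound 4 (0.03 log units; within the scatter) and likewise stays within the scatter: the same change on two cores in this assay, a 1.2-fold higher number (0.07 log units; within the scatter) from compound 1 to compound 3 and a 1.1-fold lower number (0.03 log units; within the scatter) from compound 2 to compound 4, 1.3-fold (0.10 log units) apart, within the scatter of two such steps. The four compounds thus form a closed square in which each single change stays within the scatter, so in this assay phenyl and cyclopentyl cannot be told apart on this nitrogen, nor fluoro and hydrogen on that carbon.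

On these data alone, whether a benzyl group, a longer alkyl chain or a chain ending in an amine on this nitrogen would move the number beyond the scatter remains open. So does the effect of a methoxy group or a chloro group on that aromatic carbon.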